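Swapping dichlorophenyl for dimethylphenyl on a piperazine-linked quinazoline

The source may hold more compounds than are shown below. What is called first, only, known or untested is meant among the compounds shown, and "the series" means these compounds.

Of the compounds shown here, three have been tested in a functional assay on HT-29 cells (Homo sapiens) for cytotoxicity, read by MTT assay, with a stated time of 2 days, tested at 10 uM; a higher number here means more inhibition at the concentration tested (going by the name of the read-out), a lower number less inhibition. Compound 1 `CN(C)CCNc1nc(NCc2ccco2)c2ccccc2n1`, the smallest of the set, gives 21.7%. Compound 2 `Fc1ccc2nc(NCCCCN3CCN(c4cccc(Cl)c4Cl)CC3)nc(NCc3ccco3)c2c1`, which carries a long chain ending in an amine in a ring that bears a 2,3-dichlorophenyl group, gives 96.3%. Compound 3 `Cc1cccc(N2CCN(CCCNc3nc(NCc4ccco4)c4cc(F)ccc4n3)CC2)c1C`, with a 2,3-dimethylphenyl group on the corresponding ring nitrogen, gives 96.7%.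

Among these three numbers compound 2 stands second highest. Its nearest neighbour is compound 3, whose number lies within the usual scatter of compound 2, so the two cannot be told apart. Its furthest neighbour is compound 1, whose number lies far below, well beyond the scatter.

The next compound, compound 4 `Cc1cccc(N2CCN(CCCCNc3nc(NCc4ccco4)c4cc(F)ccc4n3)CC2)c1C`, has not yet been measured. It differs from compound 2 in one place: 2,3-dimethylphenyl in place of 2,3-dichlorophenyl on an amine nitrogen in a ring.

Going by the values given here, no step between two measured compounds isolates this change. Still, compound 3 already carries the 2,3-dimethylphenyl group and in this assay compound 3 gives 96.7%, which sits where compound 2 does. The expected step of a number 1.3 percentage points lower from compound 2 to compound 4 (within the scatter) is therefore none beyond the scatter. Compound 4 is estimated at 95%, within a range from 85% to 99%.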

Compound 4, a percentage reported as inhibition, at one concentration (the size of the read-out at that concentration, not a potency): 96.1%
Compound 4: the middle estimate sits 1.1 percentage points below what was measured; low and high end bracket the measured number.
By their numbers in this assay, from the lowest: compound 1; then compounds 4, 2 and 3 (each within the scatter of the next).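

In this assay, going by these compounds alone, 2,3-dimethylphenyl in place of 2,3-dichlorophenyl on an amine nitrogen in a ring gives a number 0.2 percentage points lower from compound 2 to compound 4 (within the scatter), the first reading of this change with the rest of the structure held the same. The earlier compounds shown here contained no pair differing only in this place, whereas this pair shows that the two carbon-ring groups, with the same count of heavy atoms, cannot be told apart here. No measurement shown explains why the number stays level across this change.

The read-out gives the size of the effect at one concentration rather than a potency, so compound 2 at 96.3% and compound 4 at 96.1% could still separate in a test across several concentrations. Also open, going by these compounds, is how a plain phenyl group or a 2-pyridyl group on the same amine nitrogen in a ring would read in this assay, and whether such a group would also leave the number within the scatter of compound 2.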